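The compounds below may be only part of what the source reports. "The series", "measured", "known", "first", "only" and "open" are said of these compounds alone.

In a functional assay on CCRF-CEM cells (Homo sapiens) for antiproliferative activity (a lower number here means a stronger inhibitor of growth, a higher number a weaker inhibitor of growth), compound 2 `COCCCCCCCCCCC/C=C1\CC(CO)(COC(=O)C(C)(C)C)OC1=O` gives 0.701 ug/mL and compound 3 `CCCCCOCCCCCCC/C=C1\CC(CO)(COC(=O)C(C)(C)C)OC1=O` gives 0.877 ug/mL, with a 1.3-fold higher number from compound 2 to compound 3 (0.10 log units; within the scatter). Compound 1 `COCCCCCCCCCCCCCCC/C=C1\CC(CO)(COC(=O)C(C)(C)C)OC1=O` gives 4.26 ug/mL, and both other compounds differ from it beyond the scatter: a 6.1-fold lower number from compound 1 to compound 2 (0.78 log units; beyond the scatter), and a 4.9-fold lower number from compound 1 to compound 3 (0.69 log units; beyond the scatter).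

The change to compound 4 `CC(=O)OCCCCCCCCCCCCCCC/C=C1\CC(CO)(COC(=O)C(C)(C)C)OC1=O` is 4-acetoxybutyl in place of methoxy on a saturated chain carbon, ten or more bonds along the chain from a double-bonded chain carbon. The closest evidence is the measured step from compound 1 to compound 2, a 6.1-fold lower number from compound 1 to compound 2 (0.78 log units; beyond the scatter), which takes away a 4-methoxybutyl where this change adds a 4-acetoxybutyl. A modest rise in this assay of similar size is therefore expected. Among the compounds with values here, no measured compound carries the acetoxy end, so the range stays wide. The estimated step is a 5.0-fold higher number from compound 2 to compound 4 (0.70 log units; beyond the scatter). The expected value for compound 4 is 3.5 ug/mL, within 1.2 ug/mL to 10 ug/mL.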

Compound 4, concentration for 50% growth inhibition: 7.55 ug/mL
Compound 4: middle estimate off by 2.2-fold (0.33 log units), on the low side; measured number inside the range.
By their numbers in this assay, from the lowest: compounds 2 and 3 (each within the scatter of the next); then compounds 1 and 4 (each within the scatter of the next).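

In this assay, acetyl in place of methyl on an oxygen on a saturated carbon gives a 1.8-fold higher number from compound 1 to compound 4 (0.25 log units; within the scatter), so the two end groups are not told apart on this chain. The acetoxy end joins the methoxy end on the high side: 4-acetoxybutyl in place of methoxy gives an 11-fold higher number from compound 2 to compound 4 (1.03 log units; beyond the scatter), and 8-acetoxyoctyl in place of pentyloxy gives an 8.6-fold higher number from compound 3 to compound 4 (0.93 log units; beyond the scatter). Nothing at hand gives a cause for these steps.

Still open, as far as these compounds go, is whether an acetoxy end on the shorter chain of compound 2 would match compound 2. From the compounds shown here alone, a free hydroxyl, an amine or a carboxylic acid at the end of the longer chain also remains open.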